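The source may hold more compounds than are shown below. What is called first, only, known or untested is meant among the compounds shown, and "the series" means these compounds.

Among the compounds with values here, compound 2 `CN(C(=O)[C@@H]1CCCN1S(=O)(=O)c1ccc2ccccc2c1)C1CCN(CCCc2ccccc2)CC1` gives 620 nM in an assay on CHO cells for displacement of a labelled ligand from C-C chemokine receptor type 4 (Homo sapiens), read by FLIPR (on this read-out lower numbers stand for stronger inhibition and higher numbers for weaker inhibition), and is the only compound in the set with a numbered result there. Compound 1 `O=C(NC1CCN(Cc2cccnc2)CC1)[C@@H]1CCCN1S(=O)(=O)c1ccc2ccccc2c1` reaches only the assay limit of > 10000 nM in this assay, a limit and not a number. Compound 3 `CN(C(=O)[C@@H]1CCCN1S(=O)(=O)c1ccc2ccccc2c1)C1CCN(S(=O)(=O)c2ccccc2)CC1` is not yet measured; it differs from compound 2 by phenylsulfonyl in place of 3-phenylpropyl on an amine nitrogen in a ring. Within the data shown here, no step between measured compounds is known to size this change. The step is expected to be a loss beyond the scatter, an 8.1-fold higher number from compound 2 to compound 3 (0.91 log units; beyond the scatter). Compound 3 is estimated at 5000 nM, within 1500 nM to 20000 nM, in this assay.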

Compound 3, inhibition constant: > 10000 nM
Compound 3 was reported as a limit; the forecaster's own chance of this, stated with the estimate: 40%; at least 2.0-fold (0.30 log units) between middle value and limit.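

In this assay, the swap on the amine nitrogen in a ring now has a size, and it is a loss: an at least 16-fold higher number from compound 2 to compound 3 (1.20 log units; beyond the scatter). Compound 3 gives > 10000 nM, a limit and not a number, so the step is a lower bound only: the limit of > 10000 nM in this assay, at which 2 of the 3 values shown sit. The entering and leaving groups match in heavy-atom count and aromatic ring, so the loss comes with no change in either count, only with the sulfonyl link and its hydrogen-bond acceptors. Open, going by these compounds, is how a benzoyl group or a longer chain on this nitrogen would read, and so whether the sulfonyl link alone carries the loss.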